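Phenyl to 3-fluorophenyl: what one measured step suggests

The source may report more compounds than this note shows. Statements on the series, on what has been measured and on what is new or still open speak of the compounds shown alone.

Measured so far in a functional assay on SiHa cells (Homo sapiens) for antiproliferative activity, read by MTT assay, with a stated time of 48 h (on this read-out lower numbers stand for stronger inhibition and higher numbers for weaker inhibition), are two compounds:
- Compound 1 `C/C(=C\CC/C(C)=C/CC[C@@H]1[C@@]2(C)CCC(=O)C(C)(C)[C@H]2CC[C@@]1(C)O)CC/C=C(\C)C(=O)OCc1cn(-c2cccc(Cl)c2)nn1` gives 111000 nM
- Compound 2 `C/C(=C\CC/C(C)=C/CC[C@@H]1[C@@]2(C)CCC(=O)C(C)(C)[C@H]2CC[C@@]1(C)O)CC/C=C(\C)C(=O)OCc1cn(-c2ccccc2)nn1` gives 149000 nM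

Of these two numbers, compound 2 holds the higher one, but it stands level with compound 1 within the scatter. Compound 3 `C/C(=C\CC/C(C)=C/CC[C@@H]1[C@@]2(C)CCC(=O)C(C)(C)[C@H]2CC[C@@]1(C)O)CC/C=C(\C)C(=O)OCc1cn(-c2cccc(F)c2)nn1` has not yet been measured. It differs from compound 2 by one change: fluoro in place of hydrogen on an aromatic carbon, meta to a large group. Within the data shown here, only one measured step bears on this, and it concerns the same aromatic carbon, where compound 1 carries chloro: a 1.3-fold higher number from compound 1 to compound 2 (0.13 log units; within the scatter). A single step within the scatter is thin evidence, yet it gives no reason to expect a real shift from this small replacement. The expected step is a 1.1-fold lower number from compound 2 to compound 3 (0.06 log units; within the scatter), which is none beyond the scatter in this assay as far as can be judged. The estimate for compound 3 is 130000 nM with an expected range of 80000 nM to 200000 nM for the coming measurement.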

Compound 3, half-maximal inhibitory concentration: > 150000 nM
Compound 3 was reported as a limit; the forecaster's own chance of this, stated with the estimate: 10%; middle value at least 1.1-fold (0.06 log units) from the limit.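

In this assay compound 3 is reported only as a limit of the assay, not as a number: the limit of > 150000 nM in this assay, at which 1 of the 3 values shown sits. This adds one thing to the earlier pair: with a number no lower from compound 2 to compound 3 (the limit leaves the size open) fluoro on this aromatic carbon gives no sign of stronger inhibition than hydrogen. Fluoro in place of chloro on the same carbon gives an at least 1.3-fold higher number from compound 1 to compound 3 (0.13 log units; that floor lies within the scatter), so the compounds shown cannot tell whether the true gap between these two halogens exceeds the scatter.

As far as these compounds go, it remains open how far the number of compound 3 actually lies from those of compound 1 and compound 2. From the compounds shown here alone, it is also open whether an amine, a carboxylic acid or a methoxy group on this carbon would move the number beyond the scatter in either direction.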